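Methyl to trifluoromethyl: what clearance to expect for compound 4

This account rests on a few compounds, and the source may have more. Where it says the series, first, only, none or still open, it means among the compounds named here.

Measured in an ADME assay on microsomes from liver (Homo sapiens) for metabolic stability; a higher number here means faster removal of the compound, a lower number slower removal:
Compound 1 `CCCC(Oc1ccc(-n2cc(C(F)(F)F)c(C)n2)cc1)c1ccc(C(=O)NCCC(=O)O)cc1`: < 10 mL/min/kg (a limit)
Compound 2 `CCCC(Oc1ccc(-n2cc(C#N)cn2)cc1)c1ccc(C(=O)NCCC(=O)O)cc1`: < 8 mL/min/kg (a limit)
Compound 3 `CCCC(Oc1ccc(-n2cc(C)cn2)cc1)c1ccc(C(=O)NCCC(=O)O)cc1`: 16 mL/min/kg

Compound 3 is the only one of the three with an actual number in this assay, as the other two values are limits. Compound 4 `CCCC(Oc1ccc(-n2cc(C(F)(F)F)cn2)cc1)c1ccc(C(=O)NCCC(=O)O)cc1` has not yet been measured. It differs from compound 3 in one place, trifluoromethyl in place of methyl on an aromatic carbon.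

Going by the values given here, two measured steps bear on this change. The closer one is an at least 1.6-fold higher number from compound 1 to compound 3 (0.20 log units; that floor lies within the scatter); compound 1 carries 3-methyl-4-(trifluoromethyl)-1H-pyrazol-1-yl, so it also has trifluoromethyl. The other is an at least 2.0-fold higher number from compound 2 to compound 3 (0.30 log units; that floor lies within the scatter), which involves cyano rather than trifluoromethyl. As far as these compounds go, both give only floors, so their true sizes remain open, but they point the same way, and a modestly lower number is expected. The expected change is a 1.8-fold lower number from compound 3 to compound 4 (0.25 log units; within the scatter). For compound 4 the estimate is 9 mL/min/kg, with an expected range of 5 mL/min/kg to 16 mL/min/kg.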

Compound 4, clearance in the Homo sapiens assay: 16 mL/min/kg
Compound 4: the middle estimate sits 1.8-fold (0.25 log units) below what was measured, within the range that was stated.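

In the Homo sapiens assay, the exchange of methyl for trifluoromethyl on this aromatic carbon can now be read from two actual numbers, not from floors: compound 3 gives 16 mL/min/kg and compound 4 gives 16 mL/min/kg. In the Homo sapiens assay, this exchange gives no change at the digits printed from compound 3 to compound 4 (within the scatter). The steps to compound 4 from the other two compounds stay floors set by limits, with an at least 2.0-fold higher number from compound 2 to compound 4 (0.30 log units; that floor lies within the scatter) and an at least 1.6-fold higher number from compound 1 to compound 4 (0.20 log units; that floor lies within the scatter). In a physicochemical assay for lipophilicity, using the shake flask method, at pH 7.4 (on this read-out higher numbers stand for higher lipophilicity and lower numbers for lower lipophilicity), compound 3 gives 2.1 and compound 4 gives 2.4. In the physicochemical assay, the same exchange gives a number 0.30 log units higher from compound 3 to compound 4 (within the scatter).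

As far as these compounds go, the value of compound 1 is a limit and not a number, so what hydrogen in place of its methyl does to clearance stays unresolved: the limit of < 10 mL/min/kg in the Homo sapiens assay, at which 1 of the 4 values shown sits. Also open is what a chlorine or an ethyl group on this carbon would give in the Homo sapiens assay.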